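Aryloxy for pentan-3-yl on a shared core: acid dissociation

A few compounds are considered here, and "the series" means these few. Any claim that something is new, unique, unknown or untested is made for them only; others in the source may bear on it.

Measured so far:
compound 1, `CC(C)(C)c1ccc(Oc2ccc3c(NCCCNCc4ccco4)ccnc3c2)cc1`: 9.28
compound 2, `CCC(CC)c1ccc2c(NCCCNCc3ccco3)ccnc2c1`: 9.47

For the measured compounds named here, in a physicochemical assay for acid dissociation, compound 2 gives the highest of the two numbers known. The nearest is compound 1, whose value in this assay sits a little lower, and that gap lies within the usual scatter, so the two cannot be told apart.

Compound 3 is `COc1ccccc1Oc1ccc2c(NCCCNCc3ccco3)ccnc2c1`. It arises from compound 2 by the change (2-methoxyphenoxy in place of pentan-3-yl on an aromatic carbon). Going by the values given here, no step between measured compounds with this change is available, so the size of the step has to be judged from what the two measured compounds show.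

The move in this assay from compound 2 to compound 3 is expected to be small, if anything downward, and probably not beyond the scatter, because compound 1, which also carries an aryloxy group at the same place, gives 9.28. For compound 3 the estimate in this assay is therefore 9.3, with a range from 9 to 9.6, an expected step of a number 0.17 log units lower from compound 2 to compound 3 (within the scatter).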

Compound 3, acid dissociation constant: 9.28
Estimate against measurement, compound 3: 0.02 log units above, and the stated range covers the measured number.
By their numbers in this assay, from the lowest: compounds 1, 3 and 2 (each within the scatter of the next).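

In this assay, 2-methoxyphenoxy in place of pentan-3-yl on the aromatic carbon gives a number 0.19 log units lower from compound 2 to compound 3 (within the scatter) and so extends what compound 1 alone could suggest: a second aryloxy group at this place, with its two hydrogen-bond acceptors, also cannot be told apart from the open-chain pentan-3-yl. Within the aryloxy pair, 2-methoxyphenyl in place of 4-(tert-butyl)phenyl on the oxygen gives no change at the digits printed from compound 1 to compound 3 (within the scatter) in this assay, which shows that exchanging the substituted phenyl ring for one with a different substituent at a different place on it leaves the reading unresolved from that of compound 1, so all three compounds remain indistinguishable in this read-out. Nothing available bears on why these numbers stay so close.

The compounds shown leave open whether an amine or a carboxylic acid on this aromatic carbon would give a step beyond the scatter. They also leave open whether a longer chain in place of pentan-3-yl, or a hydrogen at this place, would read the same.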